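This account rests on a few compounds, and the source may have more. Where it says the series, first, only, none or still open, it means among the compounds named here.

Measured in an ADME assay on HepG2 cells (Homo sapiens) for cytotoxicity, read by XTT assay, with a stated time of 48 h; a higher number here means that more compound is tolerated, a lower number that less compound is tolerated
compound 1 `CCCCCCC[C@@H]1CC(O)=C(C(=O)CCC)C(=O)O1` gives "not determined" (no result reported)
compound 2 `CCCCCCCCC[C@@H]1CC(O)=C(C(=O)CCC)C(=O)O1` gives 33 ug/mL
compound 3 `CCCCCCCC[C@@H]1CC(O)=C(C(=O)CCC)C(=O)O1` gives 30 ug/mL

Among the compounds with values here, compound 3 lies within the scatter of compound 2, the only other compound with a number, so it holds no separate place in this short series. Compound 1 offers no number for comparison.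

The next compound is compound 4 `CCCCCCCCCC[C@@H]1CC(O)=C(C(=O)CCC)C(=O)O1`, which differs from compound 3 by ethyl in place of hydrogen on a saturated chain carbon, eight bonds along the chain from a saturated ring carbon.

Within the data shown here, one measured step bears on this change, at the same place on the chain: a 1.1-fold lower number from compound 2 to compound 3 (0.04 log units; within the scatter). It concerns methyl rather than ethyl, and it is a single step, so it is a thin guide. No shift beyond the scatter is expected in this assay, and no direction can be assigned.

The expected step is a 1.1-fold higher number from compound 3 to compound 4 (0.03 log units; within the scatter).

Compound 4 is estimated at 32 ug/mL with an expected range from 18 ug/mL to 55 ug/mL.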

Compound 4, half-maximal cytotoxic concentration: 25 ug/mL
For compound 4 the middle estimate is 1.3-fold (0.11 log units) above the measured one, and the stated range covers the measured number.
By their numbers in this assay, from the lowest: compounds 4, 3 and 2 (each within the scatter of the next).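

In this assay ethyl in place of hydrogen on a saturated chain carbon, eight bonds along the chain from a saturated ring carbon, gives a 1.2-fold lower number from compound 3 to compound 4 (0.08 log units; within the scatter) and the other measured step reads a 1.3-fold lower number from compound 2 to compound 4 (0.12 log units; within the scatter). The change of two heavy atoms therefore stays within the scatter, as the earlier single step did, and compound 2, compound 3 and compound 4 hold no separate places. No evidence bears on the result.

In this assay compound 1 stands as "not determined" (no result reported) and so the steps to it cannot be read. Going by these compounds, whether a longer chain, or an amine or a carboxylic acid at the chain end, would move the number beyond the scatter remains open.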